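A few compounds are considered here, and "the series" means these few. Any claim that something is new, unique, unknown or untested is made for them only; others in the source may bear on it.

Measured compounds:
compound 1 `Oc1cc(C(F)(F)F)ccc1-c1nc(-c2ccccc2O)n(-c2ccc(OC(F)(F)F)cc2)n1` — 65.5%
compound 2 `Oc1cc(C(F)(F)F)ccc1-c1nc(-c2ccccc2O)n(-c2cccc(Cl)c2)n1` — 72.3%

Both numbers come from a functional assay on PC-12 cells (Rattus norvegicus) for cytotoxicity, read by MTT assay, with stated times of 2 h and 24 h, tested at 1 uM; a higher number here means a stronger effect of the compound at the concentration tested, a lower number a weaker effect. Compound 1 gives 65.5% and compound 2 gives 72.3%; the two sit within the scatter of each other, so compound 1 stands nowhere apart from compound 2 on the numbers available. Within the data shown here, the only step measured so far, a number 6.8 percentage points higher from compound 1 to compound 2 (within the scatter), exchanges the group on the aromatic nitrogen of the shared core and leaves the read-out essentially unchanged.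

Compound 3 `Cc1cc(C)cc(-n2nc(-c3ccc(C(F)(F)F)cc3O)nc2-c2ccccc2O)c1` is not yet measured. It differs from compound 1 as follows: 3,5-dimethylphenyl in place of 4-(trifluoromethoxy)phenyl on an aromatic nitrogen

Among the measured compounds shown here, this is a change at the same position as the one measured step, which was a number 6.8 percentage points higher from compound 1 to compound 2 (within the scatter). That step bears on the present one and was within the scatter. For the measured compounds named here, no other step is available, and nothing measured shows that a second exchange at this position moves the number further. The expectation for compound 3 is therefore a step of a number 2.5 percentage points higher from compound 1 to compound 3 (within the scatter), that is, none beyond the scatter. The value of compound 3 in this assay is estimated at 68%, with a range from 55% to 80%.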

Compound 3, a percentage reported as activity, at one concentration (the size of the read-out at that concentration, not a potency): 76.9%
Estimate against measurement, compound 3: 8.9 percentage points below, and the stated range covers the measured number.
By their numbers in this assay, from the lowest: compounds 1, 2 and 3 (each within the scatter of the next, the first and the last beyond it).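

Working notes on the group on the aromatic nitrogen: in this assay, the exchange of 4-(trifluoromethoxy)phenyl for 3,5-dimethylphenyl gives the first step in the series that lies beyond the scatter (a number 11.4 percentage points higher from compound 1 to compound 3 (beyond the scatter)), so the read-out is not indifferent to the group at this position, although the step is modest. The exchange of 3-chlorophenyl for 3,5-dimethylphenyl stays within the scatter (a number 4.6 percentage points higher from compound 2 to compound 3 (within the scatter)), so these two groups cannot be told apart here, and compound 2 lies within the scatter of both compound 1 and compound 3; only the two end members of the series are separated. No measurement on hand bears on what lies behind the step.

On these data alone, all three groups at this position are substituted phenyl rings, so it remains open how the read-out responds to a saturated amine such as piperidine, or to a phenyl ring carrying a carboxylic acid. As far as these compounds go, it also remains open whether both methyl groups are needed for the step, which 3-methylphenyl at the same position would address.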